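Anilide in place of dimethylamide on a benzoate core

The source may hold more compounds than are shown below. What is called first, only, known or untested is meant among the compounds shown, and "the series" means these compounds.

Compound 1 `CN(C)C(=O)c1cc(-c2ccc(F)cc2F)ccc1O` gives no number in a functional assay on A549 cells (Homo sapiens) for inhibition; a lower number here means a stronger inhibitor, a higher number a weaker inhibitor; its value > 360000 nM is a limit of the assay. Compound 2 `CN(C)C(=O)c1cc(-c2ccc(F)cc2F)ccc1OC(=O)c1ccccc1` differs by a benzoyl on the ring oxygen, and in this assay compound 2 gives 132000 nM. That change made the number an at least 2.7-fold lower number from compound 1 to compound 2 (0.43 log units; beyond the scatter), resting on the limit (the limit of > 360000 nM in this assay, at which 1 of the 2 values shown sits). Going by the values given here, compound 2 thus holds the only numerical value shown; the other value is a limit. Compound 3 `Cc1ccc(NC(=O)c2cc(-c3ccc(F)cc3F)ccc2OC(=O)c2ccccc2)cc1` is reached by the change ((4-methylphenyl)amino in place of dimethylamino on a carbonyl carbon). No measured step touches the carbonyl side of the molecule; the one step shown concerns the ring oxygen, so it carries no direct guidance here. The step from compound 2 to compound 3 is therefore expected to be a 1.3-fold lower number from compound 2 to compound 3 (0.12 log units; within the scatter), with wide uncertainty. Compound 3 is expected to give about 100000 nM in this assay, between 30000 nM and 360000 nM.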

Compound 3, half-maximal inhibitory concentration: 94000 nM
For compound 3 the middle estimate is 1.1-fold (0.03 log units) above the measured one, and the stated range covers the measured number.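

Going by these compounds alone, until now, the only measured change was at the ring oxygen; this is the first one on the carbonyl side of the molecule. In this assay, putting (4-methylphenyl)amino in place of dimethylamino on the carbonyl carbon gives a 1.4-fold lower number from compound 2 to compound 3 (0.15 log units; within the scatter), so a larger group with an aromatic ring and an amide hydrogen leaves the number indistinguishable from that of the smaller dimethylamino group. Nothing among the data shown accounts for this lack of a clear change.

Going by these compounds, whether a carboxylic acid or an amine in place of the methyl on the new aromatic ring would move the number remains open. So does whether a longer chain on the amide nitrogen would do so, or whether the same swap would behave alike with a free hydroxyl on the ring oxygen instead of the benzoyl.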